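Exchanging halogen patterns on the aryl ring of compound 3

A few compounds are considered here, and "the series" means these few. Any claim that something is new, unique, unknown or untested is made for them only; others in the source may bear on it.

Measured so far:
compound 1 `O=C(Nc1ccc(Oc2ccnc3[nH]ccc23)cc1)c1cn(-c2ccc(F)c(Cl)c2)c2ccccc2c1=O` — 4810 nM
compound 2 `O=C(Nc1ccc(Oc2ccnc3[nH]ccc23)c(F)c1)c1cn(-c2ccccc2)c2ccccc2c1=O` — 420 nM
compound 3 `O=C(Nc1ccc(Oc2ccnc3[nH]ccc23)c(F)c1)c1cn(-c2ccc(Br)cc2F)c2ccccc2c1=O` — 1150 nM

In a functional assay on A549 cells (Homo sapiens) for inhibition, read by MTT assay, with a stated time of 72 h (a higher number here means a weaker inhibitor, a lower number a stronger inhibitor), compound 3 gives 1150 nM, which places it second highest of the three numbers. Compound 2 gives 420 nM and sits nearest to compound 3; compound 1 gives 4810 nM and lies furthest from it. Going by the values given here, the one step computed between the measured compounds is a 2.7-fold higher number from compound 2 to compound 3 (0.44 log units; beyond the scatter). The new compound 4 `O=C(Nc1ccc(Oc2ccnc3[nH]ccc23)c(F)c1)c1cn(-c2ccc(F)c(Cl)c2)c2ccccc2c1=O` carries the change (3-chloro-4-fluorophenyl in place of 4-bromo-2-fluorophenyl on an aromatic nitrogen). Among the compounds with values here, no measured step shows this exact exchange, but compound 1 carries the same 3-chloro-4-fluorophenyl group and gives a weaker number in this assay than compound 2 or compound 3, while compound 1 also lacks the fluorine that compound 2, compound 3 and compound 4 share. Weighing these, the step from compound 3 to compound 4 is expected to be a 1.7-fold higher number from compound 3 to compound 4 (0.24 log units; within the scatter). Compound 4 is therefore estimated at 2000 nM, within a range from 700 nM to 6000 nM.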

Compound 4, half-maximal inhibitory concentration: 2150 nM
For compound 4 the middle estimate is 1.1-fold (0.03 log units) below the measured one; the range from low to high includes it.
By their numbers in this assay, from the lowest: compound 2; then compounds 3 and 4 (each within the scatter of the next); then compound 1.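

In this assay, the two halogen patterns on the aryl ring cannot be told apart: the exchange gives a 1.9-fold higher number from compound 3 to compound 4 (0.27 log units; within the scatter). Set against the unsubstituted phenyl, however, the 3-chloro-4-fluorophenyl group gives a 5.1-fold higher number from compound 2 to compound 4 (0.71 log units; beyond the scatter), so both halogenated aryl groups shown on this aromatic nitrogen give higher numbers than phenyl, and compound 2 goes with neither of them. With the 3-chloro-4-fluorophenyl group held constant, the pair also isolates a change elsewhere in the molecule, fluoro in place of hydrogen on an aromatic carbon, which gives a 2.2-fold lower number from compound 1 to compound 4 (0.35 log units; beyond the scatter).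

Going by these compounds, whether a methoxy or an amine on this aryl ring would give a number at or below that of compound 2 remains open, as does whether the fluoro step holds with other aryl groups. Nothing measured here explains any of these steps.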